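Thiophene series: aryl swap at the sulfur-flanked carbon

The source may report more compounds than this note shows. Statements on the series, on what has been measured and on what is new or still open speak of the compounds shown alone.

Measured so far:
compound 1 `COc1ccc(-c2sc(N)c(C(=O)c3ccc(Cl)cc3)c2C)cc1` — 1%
compound 2 `Cc1c(Br)sc(N)c1C(=O)c1ccc(Cl)cc1` — 1%
compound 3 `CC(C)(C)Cc1c(-c2ccoc2)sc(N)c1C(=O)c1ccc(Cl)cc1` — 1%

All three compounds sit at the floor of an assay on CHO cells for displacement of a labelled ligand from adenosine receptor A1 (Homo sapiens), read by scintillation counting, tested at 10 uM; on this read-out higher numbers stand for more inhibition at the one concentration tested (going by the name of the read-out) and lower numbers for less inhibition. Compound 3 is level with compound 1 and compound 2 at the digits shown; the step of no change at the digits printed from compound 1 to compound 2 (within the scatter) is within the scatter, and the gap between compound 3 and either neighbour is likewise within the scatter. Among the measured compounds shown here, no compound gives a higher or lower number than another here.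

Compound 4 `CC(C)(C)Cc1c(-c2ccc(Cl)cc2)sc(N)c1C(=O)c1ccc(Cl)cc1` is the next step from compound 3: 4-chlorophenyl in place of furan-3-yl on an aromatic carbon. For the measured compounds named here, the only measured step at this position, bromo in place of 4-methoxyphenyl from compound 1 to compound 2, shows no change at the digits printed from compound 1 to compound 2 (within the scatter), and compound 1, which already carries a six-membered aromatic ring at the same carbon, gives 1%. Going by the values given here, nothing among the measured compounds points to movement at this position, so the expected step is no change at the digits printed from compound 3 to compound 4 (within the scatter), none beyond the scatter. Compound 4 is therefore estimated at 1%, with a range from -6% to 12%.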

Compound 4, a percentage reported as inhibition, at one concentration (the size of the read-out at that concentration, not a potency): 1%
The estimate for compound 4 equals the measured number at the digits printed; low and high end bracket the measured number.
By their numbers in this assay, from the lowest: compounds 1, 2, 3 and 4 (each within the scatter of the next).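

In this assay, 4-chlorophenyl in place of furan-3-yl on the aromatic carbon next to the ring sulfur gives no change at the digits printed from compound 3 to compound 4 (within the scatter). The earlier step at this position exchanged an aromatic ring for bromo, whereas this one exchanges one aromatic ring for another: a five-membered ring with a hetero atom for a six-membered ring of carbon only, with the neopentyl group in place on the neighbouring ring atom. The read-out does not separate these two rings, and no measurement on hand offers a reason for that.

The compounds shown leave open whether an amine or a carboxylic acid on this carbon would read any differently from these aromatic rings. Also open, from the compounds shown here alone, is whether a longer chain in place of the neopentyl group would change the reading.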